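Compound 3 to compound 4: phenyl to piperazin-1-yl

The compounds below may be only part of what the source reports. "The series", "measured", "known", "first", "only" and "open" are said of these compounds alone.

In a functional assay on C6 cells (Rattus norvegicus) for inhibition, read by sulforhodamine B assay, with a stated time of 72 h (a higher number here means that more compound is needed for the effect, a lower number that less compound is needed), compound 1 (`CSc1ccc(C(=O)/C=C/c2ccc([N+](=O)[O-])o2)cc1`) gives 1600 nM, compound 2 (`CC(C)(C)c1ccc(C(=O)/C=C/c2ccc([N+](=O)[O-])o2)cc1`) gives 28600 nM and compound 3 (`O=C(/C=C/c1ccc([N+](=O)[O-])o1)c1ccc(-c2ccccc2)cc1`) gives 17700 nM. Compound 3 therefore stands within the scatter of compound 2 and far from compound 1, which has the lowest number of the three.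

Compound 4 (`O=C(/C=C/c1ccc([N+](=O)[O-])o1)c1ccc(N2CCNCC2)cc1`) carries piperazin-1-yl in place of phenyl on an aromatic carbon, para to a large group: piperazin-1-yl in place of phenyl on an aromatic carbon.

All three measured steps change this same place. Phenyl in place of methylsulfanyl gives an 11-fold higher number from compound 1 to compound 3 (1.04 log units; beyond the scatter), and tert-butyl in place of methylsulfanyl gives an 18-fold higher number from compound 1 to compound 2 (1.25 log units; beyond the scatter). Both are large. Phenyl in place of tert-butyl gives a 1.6-fold lower number from compound 2 to compound 3 (0.21 log units; within the scatter), which is within the scatter. Among these three groups, only methylsulfanyl holds a hetero atom, and piperazin-1-yl holds hetero atoms too. That is a thin basis, resting on three compounds, and no measured group has a non-aromatic ring. A moderate move toward a lower number is therefore expected, though not all the way back to compound 1, and the expectation stays uncertain: a 3.0-fold lower number from compound 3 to compound 4 (0.47 log units; beyond the scatter).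

For compound 4, the estimated value in this assay is 6000 nM, with an expected range of 1300 nM to 26000 nM.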

Compound 4, half-maximal effective concentration: 1500 nM
For compound 4 the middle estimate is 4.0-fold (0.60 log units) above the measured one; low and high end bracket the measured number.
By their numbers in this assay, from the lowest: compounds 4 and 1 (each within the scatter of the next); then compounds 3 and 2 (each within the scatter of the next).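

In this assay, among the compounds shown here, piperazin-1-yl on this aromatic carbon gives a 12-fold lower number from compound 3 to compound 4 (1.07 log units; beyond the scatter) in place of phenyl and a 19-fold lower number from compound 2 to compound 4 (1.28 log units; beyond the scatter) in place of tert-butyl at this position, so methylsulfanyl is no longer the only group here that gives a low number. Against methylsulfanyl itself, the change reads a 1.1-fold lower number from compound 1 to compound 4 (0.03 log units; within the scatter) and leaves the two groups indistinguishable, although one is a non-aromatic ring with two hetero atoms and the other has no ring. Across these four compounds, the two groups holding hetero atoms group together at the low end and the two carbon-only groups at the high end, with no compound going against this, while phenyl and piperazin-1-yl have the same count of heavy atoms, so that count alone does not separate the numbers.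

Nothing available on these compounds explains why the number changes at this position.

Going by these compounds, whether the ring, its free amine hydrogen or simply a nitrogen on the aromatic carbon tracks with the low number stays open, and morpholin-4-yl, piperidin-1-yl, 4-methylpiperazin-1-yl or dimethylamino at this place would help separate these possibilities.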